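This account rests on a few compounds, and the source may have more. Where it says the series, first, only, none or still open, it means among the compounds named here.

For the measured compounds named here, in a functional assay on HL-60 cells (Homo sapiens) for cytotoxicity, read by MTT assay (a lower number here means a stronger inhibitor, a higher number a weaker inhibitor), two compounds sharing one core have numbers so far. Compound 1 `COc1ccc(S(=O)(=O)NC(C2=CC(=O)c3c(O)ccc(O)c3C2=O)C(C)C)c(OC)c1` gives 400 nM, and compound 2 `COc1ccc(S(=O)(=O)NC(C)C2=CC(=O)c3c(O)ccc(O)c3C2=O)c(OC)c1` gives 500 nM. Compound 2 thus stands level with compound 1, since the two values lie within the scatter of each other.

The next compound, compound 3 `CC(=O)c1ccc(S(=O)(=O)NC(C)C2=CC(=O)c3c(O)ccc(O)c3C2=O)cc1`, keeps the core and chain of compound 2 and changes only the group on the sulfonyl sulfur: 4-acetylphenyl in place of 2,4-dimethoxyphenyl on a sulfonyl sulfur. In words, this is 4-acetylphenyl in place of 2,4-dimethoxyphenyl on a sulfonyl sulfur.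

Going by the values given here, only one measured step is available, a 1.3-fold higher number from compound 1 to compound 2 (0.10 log units; within the scatter), and it lies within the scatter. That step changes the saturated chain carbon, not the group on the sulfonyl sulfur, so it bears on the new change only indirectly. Among the compounds with values here, no measured pair varies the group on the sulfonyl sulfur, so the data give no direction for this change. No shift beyond the scatter is expected in this assay, though the uncertainty is wide.

The expected step is no change at the digits printed from compound 2 to compound 3 (within the scatter). Compound 3 is estimated at 500 nM, with an expected range from 170 nM to 1500 nM.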

Compound 3, half-maximal inhibitory concentration: 260 nM
Estimate against measurement, compound 3: 1.9-fold (0.28 log units) above; measured number inside the range.
By their numbers in this assay, from the lowest: compounds 3, 1 and 2 (each within the scatter of the next).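

In this assay, for the compounds shown here, the group on the sulfonyl sulfur can now be read for the first time: 4-acetylphenyl in place of 2,4-dimethoxyphenyl gives a 1.9-fold lower number from compound 2 to compound 3 (0.28 log units; within the scatter) and so stays within the scatter. The earlier step concerned only the saturated chain carbon, whereas this one shows that the aryl group on the sulfonyl sulfur can be exchanged, here for one carrying an acetyl group rather than two methoxy groups, without a shift that can be told apart from repeat measurement. No measured evidence bears on why these two groups read alike in this assay.

What the compounds shown leave open is whether any group on the sulfonyl sulfur moves the number beyond the scatter, for instance a plain methyl, or a phenyl ring carrying an amine or a carboxylic acid. From the compounds shown here alone, it also remains open whether the isopropyl and methyl chains stay level with each other when 4-acetylphenyl, rather than 2,4-dimethoxyphenyl, sits on the sulfonyl sulfur.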